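This account rests on a few compounds, and the source may have more. Where it says the series, first, only, none or still open, it means among the compounds named here.

In an ADME assay on MT4 cells (Homo sapiens) for cytotoxicity, read by MTT assay, with a stated time of 96 h (on this read-out higher numbers stand for lower toxicity in this test and lower numbers for higher toxicity in this test), compound 3 `Brc1ccc(NCc2cn(-c3ccccc3)nc2-c2ccc(Br)cc2)cc1` gives > 100000 nM, which is a limit of the assay rather than a number. Compound 1 `Clc1ccc(NCc2cn(-c3ccccc3)nc2-c2ccc(Br)cc2)cc1` gives > 100000 nM; > 100000 nM (2 entries) in this assay, again only a limit. Compound 2 `Cc1ccc(NCc2cn(-c3ccccc3)nc2-c2ccc(Br)cc2)cc1` gives > 100000 nM in this assay, likewise a limit. Within the data shown here, the only step between these compounds, a step that the two limits leave unreadable from compound 2 to compound 3, cannot be sized because of the limit of > 100000 nM in this assay, at which 2 of the 3 values shown sit. Compound 4 `Brc1ccc(-c2nn(-c3ccccc3)cc2CNc2ccccc2)cc1` differs from compound 3 by hydrogen in place of bromo on an aromatic carbon. Among the measured compounds shown here, no measured step bears on this change, and all that is known is the limit of > 100000 nM in this assay, at which 2 of the 3 values shown sit, so no step beyond the scatter is expected in this assay. Compound 4 is therefore expected to give 150000 nM, with a range from 50000 nM to 500000 nM, an expected step that the limit leaves unreadable from compound 3 to compound 4, and most probably it will again be reported only as a limit.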

Compound 4, half-maximal cytotoxic concentration: > 100000 nM
Compound 4: a limit, no number (the forecaster's own chance of this, stated with the estimate: 85%); the middle value lies beyond the limit too.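

In this assay, no step can be read from compound 2 or compound 3 to compound 4, as all three give only a limit: the limit of > 100000 nM in this assay, at which 3 of the 4 values shown sit. The compounds shown leave open whether hydrogen, methyl, chloro or bromo at this place makes any difference to the half-maximal cytotoxic concentration.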